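Chloro substitution in the hydrazide series: working notes

This account rests on a few compounds, and the source may have more. Where it says the series, first, only, none or still open, it means among the compounds named here.

Measured compounds:
compound 1 `CC(=O)N(/N=C/c1ccc(Cl)cc1)c1nc(-c2ccccc2)c[se]1`: > 62000 nM
compound 2 `Cc1c[se]c(NNC(=O)c2ccccc2)n1`: > 89200 nM
compound 3 `O=C(NNc1nc(-c2ccccc2)c[se]1)c1ccccc1`: > 73000 nM

In a functional assay on DU-145 cells (Homo sapiens) for cytotoxicity, read by XTT assay, with a stated time of 72 h (on this read-out higher numbers stand for weaker inhibition and lower numbers for stronger inhibition), compound 1 gives > 62000 nM, which is a limit of the assay and not a number. Compound 2 gives > 89200 nM, again a limit. Compound 3 gives > 73000 nM, also a limit. All three values shown are therefore limits (the limit of > 62000 nM in this assay, at which 1 of the 3 values shown sits, (the limit of > 73000 nM in this assay, at which 1 of the 3 values shown sits), (the limit of > 89200 nM in this assay, at which 1 of the 3 values shown sits)), and compound 2 stands at one of them with nothing to rank it against the others. Within the data shown here, the one step between compounds that differ in a single place, a step that the two limits leave unreadable from compound 2 to compound 3, cannot be read in size or direction.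

Compound 4 `Cc1c[se]c(NNC(=O)c2ccc(Cl)cc2)n1` differs from compound 2 by chloro in place of hydrogen on an aromatic carbon. Among the measured compounds shown here, no measured step bears on a chloro entering at this place, and the single measured step gives no size to carry over. The expectation therefore rests on compound 2 alone: compound 4 is expected to remain at a limit in this assay. The expected step is a step that the limit leaves unreadable from compound 2 to compound 4. Compound 4 is estimated at 100000 nM, with a range from 30000 nM to 300000 nM.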

Compound 4, half-maximal inhibitory concentration: > 79400 nM
Compound 4 ended at the assay's limit; the forecaster's own chance of this, stated with the estimate: 80%; the middle value does not contradict the limit.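

Compound 4 gives > 79400 nM, which is a limit of the assay and not a number. Compound 2 also stands at a limit, so the step between compound 2 and compound 4 cannot be read. The compounds shown leave open what chloro in place of hydrogen on an aromatic carbon does to cytotoxicity.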